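Swapping fluoro for chloro on an aryl urea

This account rests on a few compounds, and the source may have more. Where it says the series, first, only, none or still open, it means among the compounds named here.

Measured so far, in a functional assay on HT-29 cells (Homo sapiens) for cytotoxicity, read by MTT assay, with a stated time of 72 h; a higher number here means a weaker inhibitor, a lower number a stronger inhibitor:
Compound 1, `CN(C)CCCNc1nc(-c2ccc(NC(=O)Nc3ccccc3Cl)cc2)nc2ccsc12`, gives 390 nM.
Compound 2, `CCN(CC)CCNc1nc(-c2ccc(NC(=O)Nc3ccccc3F)cc2)nc2ccsc12`, gives 610 nM.

Going by the values given here, these two compounds share a core and differ in two places at once, so no single step between them can be read from the numbers. Compound 2 stands with the highest of the two values, and its nearest neighbour, compound 1, sits within the scatter of repeated measurements, so the two cannot be ranked against each other.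

Compound 3, `CCN(CC)CCNc1nc(-c2ccc(NC(=O)Nc3ccccc3Cl)cc2)nc2ccsc12`, has not yet been measured. It is built from compound 2 by one change: chloro in place of fluoro on an aromatic carbon. Compound 1 already carries this chloro group, together with a different amine chain, and its value does not separate from that of compound 2 beyond the scatter. Among the compounds with values here, with no measured pair that isolates this exchange, the expectation for compound 3 in this assay is a step from compound 2 of a 1.3-fold lower number from compound 2 to compound 3 (0.10 log units; within the scatter), which amounts to no change beyond the scatter. The estimate for compound 3 is therefore 480 nM, with a range from 220 nM to 1100 nM.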

Compound 3, half-maximal inhibitory concentration: 620 nM
Compound 3: the middle estimate sits 1.3-fold (0.11 log units) below what was measured; measured number inside the range.
By their numbers in this assay, from the lowest: compounds 1, 2 and 3 (each within the scatter of the next).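

Going by these compounds alone, compound 2 and compound 3 are the first pair that isolates this exchange: in this assay, the move from 2-fluorophenyl to 2-chlorophenyl, on an aromatic carbon ortho to a large group, is a 1.0-fold higher number from compound 2 to compound 3 (0.01 log units; within the scatter). With the diethylamino chain in place, fluoro and chloro at this position therefore cannot be told apart in this read-out. Compound 3 also supplies a one-place comparison for the amine chain, where diethylamino in place of (dimethylamino)methyl gives a 1.6-fold higher number from compound 1 to compound 3 (0.20 log units; within the scatter), so this exchange also stays inside the usual scatter, and no information is available on what lies behind either result.

The compounds shown leave open whether the position tolerates groups beyond these two, such as bromo, methyl or methoxy, or a plain hydrogen, any of which might separate from fluoro and chloro in this assay. Also open, as far as these compounds go, is whether the fluoro and chloro exchange reads the same with the amine chain of compound 1, or with a different end to the chain, such as a morpholine or a piperidine.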